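From Hydroxy to Methoxy: Compound 2 to Compound 4

A few compounds are considered here, and "the series" means these few. Any claim that something is new, unique, unknown or untested is made for them only; others in the source may bear on it.

Compound 1 `O=C(Nc1cccc(-n2cc(-c3ccncc3)c(-c3cc(O)cc(Cl)c3)n2)c1)Nc1ccc(Cl)c(C(F)(F)F)c1`: 9.57%
Compound 2 `O=C(Nc1cccc(-n2cc(-c3ccncc3)c(-c3cc(O)cc(Cl)c3)n2)c1)Nc1ccc(Cl)c(Cl)c1`: -33.3%
Compound 3 `COc1cc(Cl)cc(-c2nn(-c3cccc(NC(=O)Nc4cc(C(F)(F)F)cc(C(F)(F)F)c4)c3)cc2-c2ccncc2)c1`: -19.5%

In a functional assay on MDA-MB-435 cells (Homo sapiens) for inhibition, read by sulforhodamine B assay, with a stated time of 48 h, tested at 10 uM (on this read-out higher numbers stand for a weaker effect at the one concentration tested and lower numbers for a stronger effect), compound 2 stands lowest of the three numbers; compound 3 lies nearest to it, and compound 1 furthest, both gaps beyond the scatter. Within the data shown here, only one single-change step is available among the measured compounds, a number 42.9 percentage points lower from compound 1 to compound 2 (beyond the scatter), and it concerns the urea-bearing aryl, not the oxygen.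

Compound 4 `COc1cc(Cl)cc(-c2nn(-c3cccc(NC(=O)Nc4ccc(Cl)c(Cl)c4)c3)cc2-c2ccncc2)c1` differs from compound 2 by methyl in place of hydrogen on an oxygen on an aromatic ring. Among the measured compounds shown here, no measured pair isolates this change. For the measured compounds named here, compound 3 carries the methoxy group too, but it also differs from compound 2 in its urea aryl, so the value of compound 3 shows only that a methoxy-bearing member of this series can also sit well below zero. The direction of the step is therefore not fixed by the data, and a step no larger than the scatter is expected in this assay, with wide uncertainty.

The estimate for compound 4 is -25%, ranging from -55% to 5%, an expected a number 8.3 percentage points higher from compound 2 to compound 4 (within the scatter).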

Compound 4, a percentage reported as activity, at one concentration (the size of the read-out at that concentration, not a potency): 0.46%
Beside the measured number, compound 4's estimate is 25.5 percentage points below it; low and high end bracket the measured number.
By their numbers in this assay, from the lowest: compound 2; then compound 3; then compounds 4 and 1 (each within the scatter of the next).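

In this assay, among these compounds, the oxygen is isolated for the first time: a number 33.8 percentage points higher from compound 2 to compound 4 (beyond the scatter), so methoxy in place of hydroxy, with the rest of the molecule unchanged, moves the number towards a weaker effect at the one concentration tested. The hydrogen on this oxygen thus makes a large difference to the read-out in this pair, which compound 3 could not show, as it also differs from compound 2 in its urea aryl. Nothing at hand explains why the step runs in this direction.

Going by these compounds, it remains open whether the same step would appear with the urea aryl of compound 1 or compound 3. Also open, on these data alone, is how an amine or an ethoxy group in place of the hydroxy would read, and so whether the free hydrogen or the added methyl governs the step.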